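Hydroxy to dimethylamino on the most active compound

This account rests on a few compounds, and the source may have more. Where it says the series, first, only, none or still open, it means among the compounds named here.

Compound 1 `COc1ccc(NC(=O)c2ncc(-c3cc(OC)c(OC)c(OC)c3)o2)cc1`: 25800 nM
Compound 2 `O=C(Nc1ccc(O)cc1)c1ncc(-c2ccc(F)cc2)o1`: > 30000 nM (a limit, not a number)
Compound 3 `O=C(Nc1ccc(O)cc1)c1ncc(-c2ccccc2)o1`: 1080 nM

In a functional assay on A549 cells (Homo sapiens) for cytotoxicity, read by CCK-8 assay (on this read-out lower numbers stand for stronger inhibition and higher numbers for weaker inhibition), compound 3 gives 1080 nM, the lower of the two true numbers, while compound 1 gives 25800 nM. Compound 2 reports only a limit, > 30000 nM.

The next compound, compound 4 `CN(C)c1ccc(NC(=O)c2ncc(-c3ccccc3)o2)cc1`, carries one change: dimethylamino in place of hydroxy on an aromatic carbon. For the measured compounds named here, no measured step touches this place. Going by the values given here, the only single-change step, an at least 27-fold lower number from compound 2 to compound 3 (1.44 log units; beyond the scatter), lies elsewhere in the molecule, but it was large and shows that one small swap can move this read-out strongly. Compound 1 differs from compound 3 in more than one place, so it does not isolate the change.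

With compound 3 already at 1080 nM, the lowest number here, a move towards weaker inhibition seems more likely than a gain. The expected step is a 2.8-fold higher number from compound 3 to compound 4 (0.44 log units; beyond the scatter), with wide uncertainty. For compound 4 the estimated value is 3000 nM, with an expected range from 500 nM to 20000 nM.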

Compound 4, half-maximal inhibitory concentration: > 30000 nM
Compound 4: only a limit was reported (the forecaster's own chance of this, stated with the estimate: 15%); at least 10-fold (1.00 log units) between middle value and limit.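

In this assay, for the compounds shown here, no earlier step touched this position on the ring, and replacing hydroxy with dimethylamino gives an at least 27-fold higher number from compound 3 to compound 4 (1.44 log units; beyond the scatter). This position therefore matters as much as the place changed between compound 2 and compound 3, and each of these single changes separates compound 3 from a compound without a true number. Compound 4 gives only a limit, not a true number, so the full size of its step remains unknown, and it shares that limit with compound 2: the limit of > 30000 nM in this assay, at which 2 of the 4 values shown sit.

The change removes the hydrogen-bond donor and also adds heavy atoms, and these two differences cannot be separated with the compounds shown. As far as these compounds go, how a plain amine or a carboxylic acid at this position would read remains open.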